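This account rests on a few compounds, and the source may have more. Where it says the series, first, only, none or still open, it means among the compounds named here.

In a functional assay on the whole organism with Cavia porcellus as the target (a lower number here means that less compound is needed, a higher number that more compound is needed for the effect), compound 1 `CCCn1cc(Cc2ccc(C(=O)NS(=O)(=O)c3ccccc3C)cc2OC)c2cc(C(=O)NCC(CC)CC)ccc21` gives 5.6 umol/kg and compound 2 `COc1cc(C(=O)NS(=O)(=O)c2ccccc2C)ccc1Cn1cc(C)c2ccc(C(=O)NCC3CCCC3)cc21` gives about 30 umol/kg. Compound 2 thus has the higher of the two numbers, by a gap beyond the usual scatter. Compound 3 `COc1cc(C(=O)NS(=O)(=O)c2ccccc2C)ccc1Cn1cc(C)c2ccc(NC(=O)CC3CCCC3)cc21` has the same atoms as compound 2, joined differently: ((cyclopentylmethyl)carbonyl)amino takes the place of (cyclopentylmethyl)carbamoyl on an aromatic carbon (((cyclopentylmethyl)carbonyl)amino in place of (cyclopentylmethyl)carbamoyl on an aromatic carbon). For the measured compounds named here, no measured pair shows what this exchange does, so the expectation is tentative: a modest fall in the required dose, estimated as a 2.5-fold lower number from compound 2 to compound 3 (0.40 log units; beyond the scatter) in this assay. The estimated value for compound 3 is 12 umol/kg, within a range of 3 umol/kg to 45 umol/kg.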

Compound 3, dose for half-maximal effect: 0.3 umol/kg
Estimate against measurement, compound 3: 40-fold (1.60 log units) above; measured number below the stated range.
By their numbers in this assay, from the lowest: compound 3; then compound 1; then compound 2.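

In this assay, turning the amide around on this aromatic carbon, with the same atoms joined differently, gives a 100-fold lower number from compound 2 to compound 3 (2.00 log units; beyond the scatter) and shows that the direction of this link alone can carry a large change at this position. The entering and leaving groups match in every count of atoms, rings, hydrogen-bond donors and acceptors, so those counts do not separate them. No measurement shown here explains the step. Going by these compounds, whether the gain would hold with a urea as the link, or with a longer chain in place of cyclopentylmethyl, stays open, as does whether it carries over to the core of compound 1.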